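Cyclic urea series: trifluoromethyl variant of compound 2

The compounds below may be only part of what the source reports. "The series", "measured", "known", "first", "only" and "open" are said of these compounds alone.

Two compounds of the shared core have been run in a functional assay on MV4-11 cells (Homo sapiens) for cytotoxicity, read by MTT assay, with a stated time of 72 h; on this read-out lower numbers stand for stronger inhibition and higher numbers for weaker inhibition. Compound 1 `CC(C)(C)c1cc(NC(=O)Nc2ccc(-c3cn4cccc(Cl)c4n3)cc2)no1` gives 353 nM. Compound 2 `Cc1cccn2cc(-c3ccc(NC(=O)Nc4cc(C(C)(C)C)on4)cc3)nc12` gives 248 nM. Going by the values given here, the single step between them, a 1.4-fold lower number from compound 1 to compound 2 (0.15 log units; within the scatter), is the only measured change at this position of the core, and on these numbers compound 2 and compound 1 stand within the scatter of each other, so no order between them can be read.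

Compound 3 `CC(C)(C)c1cc(NC(=O)Nc2ccc(-c3cn4cccc(C(F)(F)F)c4n3)cc2)no1` is the next variant at the same place. The change from compound 2 is trifluoromethyl in place of methyl on an aromatic carbon. Among the compounds with values here, the one step that bears on it is the exchange at this carbon from compound 1 to compound 2, which was within the scatter. With no measured step beyond the scatter at this position, a step of no size beyond the scatter is expected in this assay for compound 3, in neither direction. Compound 3 is therefore estimated at 280 nM, range 120 nM to 650 nM, which means an expected step of a 1.1-fold higher number from compound 2 to compound 3 (0.05 log units; within the scatter).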

Compound 3, half-maximal inhibitory concentration: > 900 nM
Compound 3: a limit, no number (the forecaster's own chance of this, stated with the estimate: 2%); at least 3.2-fold (0.50 log units) between middle value and limit.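

In this assay compound 3 gives > 900 nM, which is a limit of the assay and not a number. Going by these compounds alone, this carbon is not indifferent to its substituent: the exchange of chloro for methyl, a 1.4-fold lower number from compound 1 to compound 2 (0.15 log units; within the scatter), gave no readable change, whereas trifluoromethyl gives an at least 3.6-fold higher number from compound 2 to compound 3 (0.55 log units; beyond the scatter) and an at least 2.5-fold higher number from compound 1 to compound 3 (0.40 log units; beyond the scatter), the first steps beyond the scatter at this position, both towards weaker inhibition. The full size of these steps cannot be read, and the two steps fix only a minimum for the loss, since the read-out for compound 3 ends in a limit: the limit of > 900 nM in this assay, at which 1 of the 3 values shown sits.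

With methyl, chloro and trifluoromethyl the only groups shown at this carbon, nothing separates the larger count of heavy atoms in trifluoromethyl from any other difference between these groups, so the step carries no cause. As far as these compounds go, how a methoxy group, an amine or a nitrile would stand at this carbon remains open, as does whether trifluoromethyl would give a step of this kind elsewhere on the shared core.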